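The source may hold more compounds than are shown below. What is called first, only, known or untested is meant among the compounds shown, and "the series" means these compounds.

Measured so far:
- compound 1, `CC(=O)Nc1ccc2c(Cl)c(OCCCSC(=N)N)oc(=O)c2c1`: 1.13 h
- compound 2, `C[C@H](NC(=O)OC(C)(C)C)C(=O)N[C@@H](C)C(=O)Nc1ccc2c(Cl)c(OCCSC(=N)N)oc(=O)c2c1`: 0.667 h
- compound 3, `C[C@H](NC(=O)Nc1ccc2c(Cl)c(OCCSC(=N)N)oc(=O)c2c1)c1ccccc1`: 0.933 h

Three compounds that share the same core have been run in an ADME assay for pharmacokinetics; a higher number here means that the compound lasts longer, a lower number that the compound disappears faster. In this assay compound 1 gives 1.13 h, the largest of the three numbers. The gap to compound 3, which gives 0.933 h, and the gap to compound 2, which gives 0.667 h, both lie within the usual scatter of repeated measurements, so on these numbers the three compounds cannot be told apart.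

Compound 4, `N=C(N)SCCCOc1oc(=O)c2cc(NC(=O)Nc3ccccc3)ccc2c1Cl`, has not yet been measured in this assay. Compared with compound 1 it carries one change: anilino in place of methyl on a carbonyl carbon. For the measured compounds named here, no pair of measured compounds differs in exactly this way, so there is no measured step to lean on. What the three measured compounds show is that swapping the group on the amide-type nitrogen for something larger, as in compound 2 and compound 3, has not moved the half-life beyond the scatter. The expectation for compound 4 is therefore a step from compound 1 of a 1.1-fold lower number from compound 1 to compound 4 (0.05 log units; within the scatter), that is, none beyond the scatter, in no firm direction. The estimated half-life of compound 4 in this assay is 1 h, with a likely range from 0.5 h to 2 h.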

Compound 4, half-life: 2.47 h
Beside the measured number, compound 4's estimate is 2.5-fold (0.39 log units) below it, outside the stated range (above it).
By their numbers in this assay, from the lowest: compounds 2, 3 and 1 (each within the scatter of the next); then compound 4.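

For the compounds shown here, putting anilino in place of methyl on a carbonyl carbon, which turns acetamido into (phenylcarbamoyl)amino, gives in this assay a 2.2-fold higher number from compound 1 to compound 4 (0.34 log units; beyond the scatter) and is the only step here that lies beyond the scatter. Going by these compounds alone, compounds 2 and 3 differ from compound 1 in more than one place, so only this pair isolates a change at this position, and it shows that the half-life responds to the group on this carbonyl carbon, though the step is modest. Nothing shown here explains the rise, which comes with a six-membered aromatic ring and a hydrogen-bond donor entering together.

A single pair cannot separate these two parts of the change, and that would take groups such as phenyl, which brings the ring without the nitrogen, or methylamino, which brings the nitrogen without the ring. From the compounds shown here alone, it also remains open whether a substituted anilino group, such as 4-fluoroanilino, would go further, and whether the same change would give a similar step on the chain carried by compound 3.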